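This account rests on a few compounds, and the source may have more. Where it says the series, first, only, none or still open, it means among the compounds named here.

Working notes on the series. The shared core carries a propyl in compound 3 `C=CCn1ncc2c(C)nc(CCC)n2c1=O`; in a functional assay for inhibition, with Homo sapiens as the target (on this read-out higher numbers stand for weaker inhibition and lower numbers for stronger inhibition), compound 3 gives 40000 nM. Compound 2 `C=CCn1ncc2c(C)nc(C)n2c1=O` has a methyl at the same position, and in this assay compound 2 gives 73000 nM. Compound 1 `C=CCn1ncc2c(C)nc(CC)n2c1=O` carries an ethyl there. For compound 1 the result in this assay is only a limit, > 48000 nM, which is the limit of > 48000 nM in this assay, at which 1 of the 3 values shown sits. Of the two numbers shown, compound 3 and compound 2 sit within the scatter of each other, a 1.8-fold lower number from compound 2 to compound 3 (0.26 log units; within the scatter); the remaining value is the limit. The step that the limit leaves unreadable from compound 1 to compound 2 cannot be read, and an at least 1.2-fold lower number from compound 1 to compound 3 (0.07 log units; that floor lies within the scatter) has a floor inside the scatter.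

Compound 4 `C=CCn1ncc2c(C)nc(Cc3ccccc3)n2c1=O` differs from compound 3 by phenyl in place of ethyl on a saturated chain carbon bound to an aromatic carbon. The measured steps that touch this position, methyl to propyl and ethyl to propyl, are all small, so the lengthening of the chain so far has not moved this assay beyond the scatter, and the phenyl is a larger change than any of them. For compound 4 a number near that of compound 3 is expected, with a 1.6-fold lower number from compound 3 to compound 4 (0.20 log units; within the scatter) as the estimated step. The estimate for compound 4 is 25000 nM, expected to fall between 7000 nM and 90000 nM.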

Compound 4, half-maximal inhibitory concentration: > 48000 nM
Compound 4 ended at the assay's limit; the forecaster's own chance of this, stated with the estimate: 20%; middle value at least 1.9-fold (0.28 log units) from the limit.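

Compound 4 is a limit and not a number, and it is the same limit as that of compound 1 in this assay: the limit of > 48000 nM in this assay, at which 2 of the 4 values shown sit.

The change from ethyl to phenyl on a saturated chain carbon bound to an aromatic carbon, which also reads as propyl to benzyl, brings the first aromatic ring to this position and gives an at least 1.2-fold higher number from compound 3 to compound 4 (0.07 log units; that floor lies within the scatter), so no loss beyond the scatter is established, but the ring also brings no gain in inhibition over the propyl. Going by these compounds alone, the steps that link compound 4 to compound 2 and to compound 1 cannot be read, which leaves the step from compound 3 as the only comparison for the benzyl, and that comparison has only a floor.

Still open, as far as these compounds go, is how far past the limit compound 1 and compound 4 lie, and so whether ethyl and benzyl differ at all in this read-out. Also open, from the compounds shown here alone, is whether a longer chain such as butyl, or an amine or a carboxylic acid carried on the chain at this position, would move the number beyond the scatter from compound 3.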